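A few compounds are considered here, and "the series" means these few. Any claim that something is new, unique, unknown or untested is made for them only; others in the source may bear on it.

Three compounds built on one shared core were run through an ADME assay on microsomes from liver (Mus musculus) for metabolic stability, with a stated time of 30 min; on this read-out lower numbers stand for a less stable compound and higher numbers for a more stable compound. Compound 1 `Cc1nc(N2CCC(N3CCOC3=O)CC2)nc2ccc(NC(=O)/C=C/c3ccc(OC(F)(F)F)cc3)cc12` gives 74%. Compound 2 `Cc1nc(NCCNC(=O)C2CC2)nc2ccc(NC(=O)/C=C/c3ccc(OC(F)(F)F)cc3)cc12` gives 38%, and compound 3 `Cc1nc(N2CCC(N3C(=O)CCC3=O)CC2)nc2ccc(NC(=O)/C=C/c3ccc(OC(F)(F)F)cc3)cc12` gives 40%. On these numbers compound 3 stands second highest of the three: its value and that of compound 2 lie within the scatter of each other, while compound 1 sits clearly above, as the step of a number 34 percentage points lower from compound 1 to compound 3 (beyond the scatter) shows. The step of a number 36 percentage points lower from compound 1 to compound 2 (beyond the scatter) was a fall of similar size.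

The next compound, compound 4 `Cc1nc(N2CCC(N3CCCC3=O)CC2)nc2ccc(NC(=O)/C=C/c3ccc(OC(F)(F)F)cc3)cc12`, differs from compound 3 in a single place: 2-oxopyrrolidin-1-yl in place of 2,5-dioxopyrrolidin-1-yl on a saturated ring carbon. Among the measured compounds shown here, of the measured steps, only the one from compound 1 to compound 3 touches this same ring position, and it was large. The change from compound 3 to compound 4 does not bring back the group of compound 1, so only a partial recovery is expected, estimated as a number 18 percentage points higher from compound 3 to compound 4 (beyond the scatter) in this assay. Compound 4 is accordingly estimated at 58%, with a range from 40% to 76%.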

Compound 4, percent of the compound remaining: 85%
Compound 4: the middle estimate sits 27 percentage points below what was measured; measured number above the stated range.
By their numbers in this assay, from the lowest: compounds 2 and 3 (each within the scatter of the next); then compound 1; then compound 4.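

In this assay, this saturated ring carbon turns out to respond strongly even to a small edit: 2-oxopyrrolidin-1-yl in place of 2,5-dioxopyrrolidin-1-yl keeps the five-membered ring, loses one carbonyl and gives a number 45 percentage points higher from compound 3 to compound 4 (beyond the scatter). The group of compound 1 is also not the ceiling at this position, since 2-oxopyrrolidin-1-yl in place of 2-oxo-1,3-oxazolidin-3-yl gives a number 11 percentage points higher from compound 1 to compound 4 (beyond the scatter). On the aromatic carbon, 4-(2-oxopyrrolidin-1-yl)piperidin-1-yl in place of (2-((cyclopropylcarbonyl)amino)ethyl)amino gives a number 47 percentage points higher from compound 2 to compound 4 (beyond the scatter), so compound 4 stands clear of all three earlier compounds.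

Nothing at hand explains these differences. On these data alone, it remains open how a six-membered piperidin-2-one ring, or a plain pyrrolidine amine with no carbonyl, would behave on this ring carbon.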